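Methoxy for chloro on a benzylidene ketone series

This account rests on a few compounds, and the source may have more. Where it says the series, first, only, none or still open, it means among the compounds named here.

Of the compounds shown here, three of one family have numbers so far. In a functional assay on CCRF-CEM cells (Homo sapiens) for inhibition (a lower number here means a stronger inhibitor, a higher number a weaker inhibitor), compound 1, with structure `O=C1/C(=C/c2ccccc2Cl)CCCc2ccccc21`, gives 18400 nM, the lowest of the three numbers. Compound 2, `COc1cccc(/C=C2\CCc3ccccc3C2=O)c1OC`, gives 28700 nM in this assay, which sits within the usual scatter of the value of compound 1, so the two cannot be ordered. Compound 3, `O=C1/C(=C/c2ccccc2Br)Cc2ccccc21`, gives 46800 nM in this assay, a gap from compound 1 that lies beyond the scatter. No two of these three differ in only one place, so none of them shows directly how a single change moves the read-out.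

Compound 4, `COc1ccccc1/C=C1\CCCc2ccccc2C1=O`, has not yet been measured. Its difference from compound 1 is a single one, (methoxy in place of chloro on an aromatic carbon), on an aromatic carbon of a six-membered aromatic ring of carbon only. Going by the values given here, the only guide is compound 2, which carries methoxy groups and gives 28700 nM in this assay, close to compound 1. On that basis the step from compound 1 to compound 4 is expected to be small, a 1.3-fold higher number from compound 1 to compound 4 (0.12 log units; within the scatter), not clearly beyond the scatter in either direction. Compound 4 is therefore estimated at 24000 nM in this assay, in a range from 9000 nM to 65000 nM.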

Compound 4, half-maximal inhibitory concentration: 28900 nM
Beside the measured number, compound 4's estimate is 1.2-fold (0.08 log units) below it; low and high end bracket the measured number.
By their numbers in this assay, from the lowest: compounds 1, 2, 4 and 3 (each within the scatter of the next, the first and the last beyond it).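

In this assay, going by these compounds alone, methoxy in place of chloro on an aromatic carbon, ortho to a large group, gives the first direct reading of a single change in this family: a 1.6-fold higher number from compound 1 to compound 4 (0.20 log units; within the scatter), so the two compounds cannot be ordered. At this place, a group of 2 heavy atoms with 1 hydrogen-bond acceptor therefore stands in for one of 1 heavy atom with 0 hydrogen-bond acceptors, with no difference that this read-out can resolve. No measurement is available that would explain this outcome.

The compounds shown do not tell whether this tolerance extends to other groups at the same place, such as an amine, a carboxylic acid or a longer chain like butoxy, any of which could move the number beyond the scatter or leave it unchanged. Within the data shown here, they also leave open whether methoxy in place of chloro would read the same way on a different core, since this one pair is the only single change available so far.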